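This account rests on a few compounds, and the source may have more. Where it says the series, first, only, none or still open, it means among the compounds named here.

Three compounds of the series have been run in a functional assay on MCF7 cells (Homo sapiens) for cytotoxicity, read by MTT assay, with a stated time of 72 h; a lower number here means a stronger inhibitor, a higher number a weaker inhibitor. Compound 1 `COc1ncc(-c2ccc3nc(NC(=O)NC4CC4)nn3c2)cc1NS(=O)(=O)c1ccc(F)cc1` gives 300 nM in this assay. Compound 2 `CCN(CC)CCNC(=O)Nc1nc2ccc(-c3cnc(OC)c(NS(=O)(=O)c4ccc(C)cc4)c3)cn2n1` gives 410 nM in this assay, and compound 3 `CCN(CC)CCNC(=O)Nc1nc2ccc(-c3cnc(OC)c(NS(=O)(=O)c4ccc(F)cc4F)c3)cn2n1` gives 740 nM. Going by the values given here, the one single-point step among them, a 1.8-fold higher number from compound 2 to compound 3 (0.26 log units; within the scatter), concerns the aryl on the sulfonyl sulfur and nothing on the urea side. Compound 1 gives the lowest of the three numbers; its nearest neighbour is compound 2, within the scatter, and its furthest is compound 3, beyond the scatter.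

Compound 4 `COc1ncc(-c2ccc3nc(NC(=O)NCC(=O)N4CCOCC4)nn3c2)cc1NS(=O)(=O)c1ccc(F)cc1` is the next candidate for this assay. It differs from compound 1 at the urea: ((morpholin-4-yl)carbonyl)methyl in place of cyclopropyl on an amide-type nitrogen. Among the compounds with values here, no measured pair in the set changes the group on that amide-type nitrogen, so nothing measured speaks directly to this step; the only measured step sits on the sulfonyl aryl and was within the scatter. With nothing to push it either way, the step of a 1.5-fold higher number from compound 1 to compound 4 (0.18 log units; within the scatter) is expected to be modest, with a somewhat weaker outcome as plausible as no change. Compound 4 is estimated at 450 nM in this assay, with a range from 200 nM to 1200 nM.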

Compound 4, half-maximal inhibitory concentration: 630 nM
Compound 4: the middle estimate sits 1.4-fold (0.15 log units) below what was measured; measured number inside the range.
By their numbers in this assay, from the lowest: compounds 1, 2, 4 and 3 (each within the scatter of the next, the first and the last beyond it).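

In this assay, ((morpholin-4-yl)carbonyl)methyl in place of cyclopropyl on the amide-type nitrogen gives a 2.1-fold higher number from compound 1 to compound 4 (0.32 log units; beyond the scatter), so a single change at the urea moves the number beyond the scatter, whereas the sulfonyl aryl change gave only a 1.8-fold higher number from compound 2 to compound 3 (0.26 log units; within the scatter). The step remains modest even though the entering group counts 9 heavy atoms and 2 hydrogen-bond acceptors against 3 and 0 for cyclopropyl, so a substituent of this size on that nitrogen still leaves the compound active in the same assay. No measurement available here accounts for the step.

Still open, on these data alone, is which part of the entering group carries the step, the carbonyl or the morpholine ring; an ethyl chain ending in morpholine, or a carboxymethyl group on the same nitrogen, would help separate the two. Also open is how the diethylaminoethyl group of compound 2 and compound 3 compares directly with cyclopropyl, since no pair shown changes only that group while keeping the sulfonyl aryl fixed.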